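Xanthine series: acetyl for vinyl on the chain

The source may report more compounds than this note shows. Statements on the series, on what has been measured and on what is new or still open speak of the compounds shown alone.

Compound 2 `C=CCCn1cnc2c1c(=O)n(C)c(=O)n2CCC` stands at the high end of the two numbers in hand: in a functional assay (trachea) with Cavia porcellus as the target (on this read-out higher numbers stand for an effect only at larger amounts of compound and lower numbers for an effect already at smaller amounts), compound 2 gives 16800 nM, while compound 1 `CCCn1c(=O)n(CCN(C)C)c(=O)c2[nH]cnc21` gives 2700 nM in this assay, a gap beyond the scatter. Compound 1 differs from compound 2 in several places, so its value tells nothing about any single change.

Compound 3 `CCCn1c(=O)n(C)c(=O)c2c1ncn2CCC(C)=O` is not yet measured. Its change from compound 2 is acetyl in place of vinyl on a saturated chain carbon, two bonds along the chain from an aromatic nitrogen. Within the data shown here, no measured pair shows the same change, so the size of the step has no precedent in this set; a modest step in either direction, or none beyond the scatter, seems equally plausible.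

For compound 3 in this assay the estimate is 10000 nM, within 3000 nM to 40000 nM, which is expected to mean a 1.7-fold lower number from compound 2 to compound 3 (0.23 log units; within the scatter) relative to compound 2.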

Compound 3, half-maximal effective concentration: 12200 nM
Estimate against measurement, compound 3: 1.2-fold (0.09 log units) below; measured number inside the range.
By their numbers in this assay, from the lowest: compound 1; then compounds 3 and 2 (each within the scatter of the next).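

In this assay this position now has its first comparison in one place: acetyl in place of vinyl on a saturated chain carbon, two bonds along the chain from an aromatic nitrogen, gives a 1.4-fold lower number from compound 2 to compound 3 (0.14 log units; within the scatter). The hydrogen-bond acceptor that enters with acetyl, and that vinyl lacks, therefore comes with no difference beyond the scatter in this pair. Nothing on hand offers an explanation for this outcome.

Going by these compounds, whether the result holds for other groups at this place stays open: a carboxylic acid, an amine or a longer chain carrying the acetyl would each test it. A single pair also leaves open whether the same exchange would read alike on a chain of another length or with other substituents on the shared core.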